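Two Cores, One Swap, and an Expected Fourth Number

The compounds below may be only part of what the source reports. "The series", "measured", "known", "first", "only" and "open" are said of these compounds alone.

The study concerns four compounds built on two closely related cores. Compound 1 `Cc1ccccc1NC1=C/C(=N/NC(N)=S)C(=O)N=C1Nc1ccccc1C` and compound 2 `Cc1cccc(NC2=C/C(=N/NC(N)=S)C(=O)N=C2Nc2cccc(C)c2)c1` are made of the same atoms joined differently; the difference between the two cores is not broken down here. In a functional assay on HCT-116 cells (Homo sapiens) for antiproliferative activity, read by MTT assay, with a stated time of 72 h (a lower number here means a stronger inhibitor, a higher number a weaker inhibitor), compound 1 gives 1520 nM, while compound 2 gives 8650 nM.

Compound 3 `Cc1ccccc1NC1=C/C(=N/N=C(\N)SCc2ccccc2)C(=O)N=C1Nc1ccccc1C` arises from compound 1 by a single change, (a group of 11 heavy atoms (8 carbon, 2 nitrogen, 1 sulfur; one six-membered aromatic ring of carbon only) in place of a group of 4 heavy atoms (1 carbon, 2 nitrogen, 1 sulfur; no ring), on a double-bonded nitrogen), and in this assay compound 3 gives 13800 nM. That change made a step of a 9.1-fold higher number from compound 1 to compound 3 (0.96 log units; beyond the scatter). The values of compound 2 and compound 3 lie within the usual scatter of each other, so no order between them is claimed.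

Compound 4 `Cc1cccc(NC2=C/C(=N/N=C(\N)SCc3ccccc3)C(=O)N=C2Nc2cccc(C)c2)c1` has not been measured. It stands to compound 2 as compound 3 stands to compound 1: the change is a group of 11 heavy atoms (8 carbon, 2 nitrogen, 1 sulfur; one six-membered aromatic ring of carbon only) in place of a group of 4 heavy atoms (1 carbon, 2 nitrogen, 1 sulfur; no ring), on a double-bonded nitrogen, at the same place, and is therefore the same change. For the measured compounds named here, only one measured instance of it exists, so the expectation for compound 4 rests on a single step.

Compound 4 is expected to give 40000 nM in this assay, within a range from 10000 nM to 120000 nM. Going by the values given here, that estimate means a step of a 4.6-fold higher number from compound 2 to compound 4 (0.67 log units; beyond the scatter), taken somewhat smaller than the step seen once before because a 9.1-fold higher number from compound 1 to compound 3 (0.96 log units; beyond the scatter) is the only precedent and a single step is an uncertain guide on a different core.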

Compound 4, half-maximal inhibitory concentration: 12900 nM
Estimate against measurement, compound 4: 3.1-fold (0.49 log units) above, and the stated range covers the measured number.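

On the core of compound 2, the change gives a step of a 1.5-fold higher number from compound 2 to compound 4 (0.17 log units; within the scatter) in this assay, so the group with the six-membered aromatic ring of carbon only, in place of the group with no ring, leaves no readable difference on this core. The same change on the core of compound 1 gave a clearly larger step, which means that its size in this series did not carry from one core to the other: the same change on two cores in this assay, a 9.1-fold higher number (0.96 log units; beyond the scatter) from compound 1 to compound 3 and a 1.5-fold higher number (0.17 log units; within the scatter) from compound 2 to compound 4, 6.1-fold (0.78 log units) apart, beyond the scatter of two such steps

For the compounds shown here, this shows that a step measured on one of these two cores cannot be taken over unchanged to the other, even though the cores are made of the same atoms joined differently, but it rests on only two steps and does not show why they differ or how the change would behave on any further core.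

From the compounds shown here alone, it remains open how an entering group with a methyl or ethyl chain in place of the aromatic ring, or with an amine or a carboxylic acid on that ring, would behave on either core. Going by these compounds, it is also open whether the gap between the two steps would persist if chlorine replaced the methyl groups of the shared framework.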